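A few compounds are considered here, and "the series" means these few. Any claim that something is new, unique, unknown or untested is made for them only; others in the source may bear on it.

Of the compounds shown here, three from this study have been measured in a functional assay on HCT-116 cells (Homo sapiens) for cytotoxicity, read by crystal violet staining and colony formation, with a stated time of 7 days (a lower number here means a stronger inhibitor, a higher number a weaker inhibitor), and a fourth awaits its number. Compound 1, `COc1ccc(C2CC(c3c(O)ccc4ccccc34)=NN2c2ccc(Cl)cc2)c(OC)c1`, gives 5400 nM in this assay. Compound 2, `COc1cc(OC)c(C2CC(c3c(O)ccc4ccccc34)=NN2c2ccc(Cl)cc2)cc1OC`, differs from compound 1 in one place, (methoxy in place of hydrogen on an aromatic carbon), and that change made a step of a 1.4-fold higher number from compound 1 to compound 2 (0.16 log units; within the scatter). Compound 3, `COc1ccc(C2CC(c3ccc4ccccc4c3O)=NN2)cc1`, is built on a different core; the difference between the two cores is not broken down here. In this assay compound 3 gives 13200 nM, which lies beyond the scatter from compound 1 but within the scatter of compound 2, whose number is 7800 nM.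

Compound 4, `COc1ccc(C2CC(c3ccc4ccccc4c3O)=NN2)c(OC)c1`, is not yet measured. It stands to compound 3 as compound 2 stands to compound 1: methoxy in place of hydrogen on an aromatic carbon. This is the same kind of change, but the surroundings differ: in compound 2 the new methoxy sits ortho to a methoxy group, meta to a large group and para to a methoxy group, whereas in compound 4 it sits ortho to a large group and meta to a methoxy group. Because the earlier step of a 1.4-fold higher number from compound 1 to compound 2 (0.16 log units; within the scatter) stayed within the scatter, the step from compound 3 to compound 4 is expected to be small as well, about a 1.1-fold higher number from compound 3 to compound 4 (0.06 log units; within the scatter). Compound 4 is therefore expected to give roughly 15000 nM in this assay, with a likely range from 7000 nM to 32000 nM.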

Compound 4, half-maximal inhibitory concentration: 8800 nM
Compound 4: middle estimate off by 1.7-fold (0.23 log units), on the high side; measured number inside the range.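

In this assay, methoxy in place of hydrogen on an aromatic carbon made a step of a 1.5-fold lower number from compound 3 to compound 4 (0.18 log units; within the scatter), so on this core the change moved the number by no more than repeated measurements of the same compound can. Read together with the earlier step, the result gives no sign that the change behaves differently on the two cores, and on both it stays small: the same change on two cores in this assay, a 1.4-fold higher number (0.16 log units; within the scatter) from compound 1 to compound 2 and a 1.5-fold lower number (0.18 log units; within the scatter) from compound 3 to compound 4, 2.2-fold (0.34 log units) apart, within the scatter of two such steps This shows that in these two pairs the added methoxy leaves the number inside the scatter; it does not show that the methoxy has a real effect on either core, and with a single pair on each core, and the new methoxy in different surroundings in each pair, it gives no general rule for the series.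

The compounds shown leave open whether a different group on the aromatic ring, such as an amine or a carboxylic acid, would give a step beyond the scatter. They also leave open whether a longer chain in place of the methoxy would stay as close to the parent compound as the methoxy does here.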